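Notes on the shared core: ethyl in place of methoxy

This account rests on a few compounds, and the source may have more. Where it says the series, first, only, none or still open, it means among the compounds named here.

Measured so far, in an assay on isolated protein for inhibition of phosphatidylinositol 4,5-bisphosphate 3-kinase catalytic subunit beta isoform (Homo sapiens), read by 33P incorporation, with a stated time of 60 min; a higher number here means a weaker inhibitor, a lower number a stronger inhibitor:
Compound 1, `CN(/N=C/c1cnn2ccc(C#N)cc12)S(=O)(=O)c1cc([N+](=O)[O-])ccc1F`, gives 44 nM.
Compound 2, `COc1ccc([N+](=O)[O-])cc1S(=O)(=O)N(C)/N=C/c1cnn2ccc(C#N)cc12`, gives 63 nM.

Going by the values given here, compound 2 sits alongside compound 1, the only other number in this assay; the step of a 1.4-fold higher number from compound 1 to compound 2 (0.16 log units; within the scatter) falls within the scatter, so the two compounds are not separated by the data.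

Compound 3, `CCc1ccc([N+](=O)[O-])cc1S(=O)(=O)N(C)/N=C/c1cnn2ccc(C#N)cc12`, has not yet been measured in this assay. It differs from compound 2 by ethyl in place of methoxy on an aromatic carbon, at a place ortho to a large group and para to a nitro group.

Among the compounds with values here, only one measured step bears on this position: the change from fluoro to methoxy at the same aromatic carbon, a 1.4-fold higher number from compound 1 to compound 2 (0.16 log units; within the scatter), which stayed within the scatter. Within the data shown here, no measured pair covers methoxy against ethyl. On that basis the expectation for compound 3 is a step of a 1.1-fold higher number from compound 2 to compound 3 (0.05 log units; within the scatter), that is, no change beyond the scatter. Compound 3 is therefore estimated at 70 nM, with a range from 30 nM to 160 nM.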

Compound 3, half-maximal inhibitory concentration: 280 nM
For compound 3 the middle estimate is 4.0-fold (0.60 log units) below the measured one; measured number above the stated range.
By their numbers in this assay, from the lowest: compounds 1 and 2 (each within the scatter of the next); then compound 3.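

In this assay, this aromatic carbon, ortho to a large group and para to a nitro group, turns out not to be indifferent to its substituent: ethyl in place of methoxy gives a 4.4-fold higher number from compound 2 to compound 3 (0.65 log units; beyond the scatter), and ethyl in place of fluoro gives a 6.4-fold higher number from compound 1 to compound 3 (0.80 log units; beyond the scatter), both beyond the scatter, whereas fluoro and methoxy themselves could not be separated. The methoxy-to-ethyl change keeps the count of 2 heavy atoms and swaps only an oxygen for a carbon, with 1 hydrogen-bond acceptor leaving and none entering, so the position discriminates between two groups of equal heavy-atom count. Nothing available accounts for the loss seen with ethyl.

The compounds shown leave open whether a methyl, a hydroxyl or an amine on this carbon would group with fluoro and methoxy or with ethyl, and whether a longer chain such as propyl would move the number further in the same direction. Going by these compounds alone, with only three compounds, all on one core and varied at one place, it also remains open whether the ethyl step would hold if the nitro group or the nitrile were changed.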